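A Swapped Ring on the Sulfonamide Nitrogen

The source may report more compounds than this note shows. Statements on the series, on what has been measured and on what is new or still open speak of the compounds shown alone.

In a functional assay on cells (leukaemia cell line, Homo sapiens) for inhibition, read by sulforhodamine B assay, with a stated time of 48 h (on this read-out lower numbers stand for stronger inhibition of growth and higher numbers for weaker inhibition of growth), compound 1 (`O=S(=O)(Nc1ccc(Br)c(Cl)c1)c1ccc(-c2cnc(C3CC3)o2)cc1`) gives 491 nM, compound 2 (`Cc1ccc(NS(=O)(=O)c2ccc(-c3cnc(C4CC4)o3)cc2)cc1C`) gives 420 nM and compound 3 (`COc1cc(NS(=O)(=O)c2ccc(-c3cnc(C4CC4)o3)cc2)ccc1F`) gives 328 nM. Compound 1 therefore stands level with the other two, as the measured steps are a 1.2-fold lower number from compound 1 to compound 2 (0.07 log units; within the scatter) and a 1.5-fold lower number from compound 1 to compound 3 (0.18 log units; within the scatter), while the remaining one is a 1.3-fold lower number from compound 2 to compound 3 (0.11 log units; within the scatter). Compound 4 (`O=S(=O)(Nc1cc(F)cc(Cl)c1)c1ccc(-c2cnc(C3CC3)o2)cc1`) differs from compound 1 in one place: 3-chloro-5-fluorophenyl in place of 4-bromo-3-chlorophenyl on a sulfonamide nitrogen. The three measured steps change the group at this same place, and none leaves the scatter, so no step beyond the scatter is expected here either. The estimated step is a 1.2-fold lower number from compound 1 to compound 4 (0.09 log units; within the scatter). The expected value for compound 4 is 400 nM, with an estimated range of 180 nM to 900 nM.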

Compound 4, concentration for 50% growth inhibition: 1440 nM
Compound 4: middle estimate off by 3.6-fold (0.56 log units), on the low side, and the stated range ends below it.
By their numbers in this assay, from the lowest: compounds 3, 2 and 1 (each within the scatter of the next); then compound 4.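

In this assay, among the compounds shown here, the 3-chloro-5-fluorophenyl group is the first at this place on the sulfonamide nitrogen to leave the scatter, with steps (a 2.9-fold higher number from compound 1 to compound 4 (0.47 log units; beyond the scatter)), (a 3.4-fold higher number from compound 2 to compound 4 (0.54 log units; beyond the scatter)) and (a 4.4-fold higher number from compound 3 to compound 4 (0.64 log units; beyond the scatter)). This place therefore does not treat every substituted phenyl alike, even though the entering and leaving groups match in ring and heavy-atom count. Nothing available here accounts for the shift. From the compounds shown here alone, it remains open how a phenyl bearing an amine or a carboxylic acid, or a cyclohexyl ring in place of the phenyl, would fare at this place.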